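A few compounds are considered here, and "the series" means these few. Any claim that something is new, unique, unknown or untested is made for them only; others in the source may bear on it.

Compounds measured in a functional assay on HEK293 cells for agonist activity at Bombesin receptor subtype-3 (Homo sapiens), read by luminescence and calcium flux, with a stated time of 10 min; on this read-out lower numbers stand for an effect already at smaller amounts and higher numbers for an effect only at larger amounts of compound:
- compound 1, `CCC(C)(C)Cc1c[nH]c(CCc2ccc(-c3cccc(N)n3)cc2)n1`: 97 nM
- compound 2, `CCC(C)(C)Cc1c[nH]c(CCc2ccc(-c3ccns3)cc2)n1`: 102 nM

Compound 1 gives the lowest of the two numbers, but its nearest neighbour is compound 2, and the step of a 1.1-fold higher number from compound 1 to compound 2 (0.02 log units; within the scatter) lies within the scatter, so the two cannot be ordered. Among the measured compounds shown here, that single step, swapping one aromatic group for another on the same aromatic carbon, is the only one that bears on compound 3, `CCC(C)(C)Cc1c[nH]c(CCc2ccc(-n3cncn3)cc2)n1`, which differs from compound 1 as follows: 1H-1,2,4-triazol-1-yl in place of 6-aminopyridin-2-yl on an aromatic carbon. For the measured compounds named here, the one measured exchange at this position left the number unchanged, which suggests the site tolerates some variation, yet a five-membered ring attached through nitrogen and lacking a hydrogen-bond donor has not been tested here. Compound 3 is therefore expected to land close to compound 1, with a modest step of a 1.9-fold higher number from compound 1 to compound 3 (0.27 log units; within the scatter) toward a higher number, and an estimate of 180 nM within 60 nM to 600 nM.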

Compound 3, half-maximal effective concentration: 89 nM
Beside the measured number, compound 3's estimate is 2.0-fold (0.31 log units) above it; the range from low to high includes it.
By their numbers in this assay, from the lowest: compounds 3, 1 and 2 (each within the scatter of the next).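

With 1H-1,2,4-triazol-1-yl on the aromatic carbon para to a large group, this assay gives (a 1.1-fold lower number from compound 1 to compound 3 (0.04 log units; within the scatter)) and (a 1.1-fold lower number from compound 2 to compound 3 (0.06 log units; within the scatter)), so neither step separates the new compound from the earlier two. The earlier pair had shown this only for the exchange of 6-aminopyridin-2-yl with 1,2-thiazol-5-yl; the result extends it to a third aromatic group, a five-membered ring with 3 hetero atoms, and all three compounds now read alike at this position. No evidence is available on what lies behind this insensitivity.

The compounds shown leave open whether the position needs an aromatic group at all, as a morpholine ring, a carboxylic acid or a plain methyl group could behave quite differently. They also leave open whether any group here can move the number beyond the scatter.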